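The compounds below may be only part of what the source reports. "The series", "measured", "known", "first", "only" and "open" are said of these compounds alone.

For the measured compounds named here, compound 3 `COc1ccc(/C=C\c2cc(OC)c(OC)c(OC)c2)cc1OCc1ccc(CN2CCCCC2C(=O)O)cc1` holds the lowest of the two numbers measured so far in a functional assay on HepG2 cells (Homo sapiens) for antiproliferative activity, read by CCK-8 assay, with a stated time of 48 h (a lower number here means a stronger inhibitor, a higher number a weaker inhibitor), namely 3100 nM. Compound 1 `COc1ccc(/C=C\c2cc(OC)c(OC)c(OC)c2)cc1OCc1ccc(CN2CC[C@H](C(=O)O)C2)cc1` gives 6400 nM in this assay, and the step of a 2.1-fold lower number from compound 1 to compound 3 (0.31 log units; beyond the scatter) is modest. Compound 2 `COc1ccc(/C=C\c2cc(OC)c(OC)c(OC)c2)cc1OCc1ccc(CN2CCCC[C@H]2C(=O)O)cc1` reaches only a limit of this assay, > 10000 nM, rather than a number. The step of an at least 3.2-fold lower number from compound 2 to compound 3 (0.50 log units; beyond the scatter) is an at-least figure, resting on (the limit of > 10000 nM in this assay, at which 1 of the 3 values shown sits), and the two compounds part only in the fact that one of compounds 2 and 3 is drawn with a defined configuration and the other without, at the place where they differ. The unmeasured compound 4 `COc1ccc(/C=C\c2cc(OC)c(OC)c(OC)c2)cc1OCc1ccc(CNCCNC(C)=O)cc1` differs from compound 3 by (2-acetamidoethyl)amino in place of 2-carboxypiperidin-1-yl on a saturated chain carbon bound to an aromatic carbon. Going by the values given here, none of the measured steps exchanges the acid-bearing ring for an open chain, so they only bracket the size of a change in this region: an at least 1.5-fold higher number from compound 1 to compound 2 (0.19 log units; that floor lies within the scatter) stays within the scatter, while the other two reach beyond it. The account therefore expects a step of at most similar size for compound 4, with no firm direction, written as a 1.2-fold lower number from compound 3 to compound 4 (0.09 log units; within the scatter). Compound 4 is estimated at 2500 nM in this assay, between 600 nM and 9000 nM.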

Compound 4, half-maximal inhibitory concentration: 6100 nM
For compound 4 the middle estimate is 2.4-fold (0.39 log units) below the measured one; the range from low to high includes it.
By their numbers in this assay, from the lowest: compounds 3, 4 and 1 (each within the scatter of the next, the first and the last beyond it). At a limit, above all of these: compound 2.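

In this assay, the open (2-acetamidoethyl)amino chain carries neither a ring nor a carboxylic acid, yet neither exchange on the saturated chain carbon bound to an aromatic carbon moves the number beyond the scatter: a 2.0-fold higher number from compound 3 to compound 4 (0.29 log units; within the scatter), and a 1.0-fold lower number from compound 1 to compound 4 (0.02 log units; within the scatter). Among compounds 1, 3 and 4, then, neither the ring nor the carboxylic acid is shown to be needed at this place to keep a measurable number, while compound 2, which has both, goes against any reading that these groups set the number. The remaining step, an at least 1.6-fold lower number from compound 2 to compound 4 (0.21 log units; that floor lies within the scatter), gives only a floor and sets no order, as it rests on a limit: the limit of > 10000 nM in this assay, at which 1 of the 4 values shown sits.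

On these data alone, it remains open whether a carboxylic acid on an open chain would give a number different from that of the acetamide. As far as these compounds go, it is equally open whether a plain primary amine or a longer chain at this place would move the number beyond the scatter.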